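The source may hold more compounds than are shown below. What is called first, only, known or untested is meant among the compounds shown, and "the series" means these compounds.

Measured compounds:
compound 1 `Nc1ccccc1NC(=O)c1ccc(CSC(=S)N2CCN(c3ccc(Cl)cc3)CC2)cc1` — 15%
compound 2 `CC1CCCCN1C(=S)SCc1ccc(C(=O)Nc2ccccc2N)cc1` — 64.4%

In a functional assay on MGC-803 cells (Homo sapiens) for antiproliferative activity, read by CCK-8 assay, with a stated time of 72 h, tested at 2 uM (a lower number here means a weaker effect, a higher number a stronger effect of the compound at the concentration tested), compound 1 gives 15%, the lowest of the two numbers shown, while compound 2 gives 64.4%, a number higher by more than the scatter. Compound 3 `Nc1ccccc1NC(=O)c1ccc(CSC(=S)N2CCN(C3CCCCC3)CC2)cc1` has not yet been measured; it differs from compound 1 by cyclohexyl in place of 4-chlorophenyl on an amine nitrogen in a ring. Within the data shown here, no measured pair reproduces this change, so the expectation rests on the two values alone. A modest upward step is expected for compound 3, with a number 15 percentage points higher from compound 1 to compound 3 (beyond the scatter) judged to lie near the edge of the scatter. Compound 3 is therefore estimated at 30%, within a range from 10% to 60%.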

Compound 3, a percentage reported as inhibition, at one concentration (the size of the read-out at that concentration, not a potency): 16.9%
Compound 3: the middle estimate sits 13.1 percentage points above what was measured; low and high end bracket the measured number.
By their numbers in this assay, from the lowest: compounds 1 and 3 (each within the scatter of the next); then compound 2.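

In this assay, cyclohexyl in place of 4-chlorophenyl on this amine nitrogen in a ring gives a number 1.9 percentage points higher from compound 1 to compound 3 (within the scatter). At this position, then, a six-membered non-aromatic ring of carbon only and a chlorine-bearing aromatic ring cannot be told apart by this read-out at the one concentration tested. Nothing available here bears on why the two groups match. The compounds shown leave open whether a much smaller group on this nitrogen, such as methyl, would read differently. They also leave open whether a chain ending in a hydroxyl or an amine would do so.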